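Replacing 4-cyanophenyl in the series

The source may hold more compounds than are shown below. What is called first, only, known or untested is meant among the compounds shown, and "the series" means these compounds.

In an ADME assay on MDCKII-LE cells (Canis lupus familiaris) for permeability (on this read-out lower numbers stand for lower permeability and higher numbers for higher permeability), compound 2 `Cc1cnc(NC(=O)c2cc(Oc3ccc(C#N)cc3)c3cc(C)oc3c2)cn1` gives 1.5 10^-6 cm/s, the lowest of three numbers. Compound 3 `Cc1cnc(NC(=O)c2cc(Oc3ccc(C(=O)N(C)C)cc3)c3cc(C)oc3c2)cn1` gives 5.9 10^-6 cm/s, and compound 1 `Cc1cnc(NC(=O)c2cc(Oc3cnc(C(=O)N(C)C)cn3)c3cc(C)oc3c2)cn1` gives 22.3 10^-6 cm/s. The unmeasured compound 4 `CNC(=O)c1cnc(Oc2cc(C(=O)Nc3cnc(C)cn3)cc3oc(C)cc23)cn1` differs from compound 2 as follows: 5-(methylcarbamoyl)pyrazin-2-yl in place of 4-cyanophenyl on an oxygen on an aromatic ring. Going by the values given here, the only measured step bearing directly on this change is a 3.9-fold higher number from compound 2 to compound 3 (0.59 log units; beyond the scatter), modest and beyond the scatter, with dimethylcarbamoyl in place of cyano. Among the compounds with values here, compound 1 also carries dimethylcarbamoyl and gives the highest number, 22.3 10^-6 cm/s, but no measured compound carries 5-(methylcarbamoyl)pyrazin-2-yl. An upward move in this assay is therefore expected, of a size set between those two numbers: a 6.0-fold higher number from compound 2 to compound 4 (0.78 log units; beyond the scatter). The estimate for compound 4 is 9 10^-6 cm/s, with an expected range of 3 10^-6 cm/s to 22 10^-6 cm/s.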

Compound 4, apparent permeability: 20.9 10^-6 cm/s
The estimate for compound 4 lay 2.3-fold (0.37 log units) below the measured number, within the range that was stated.
By their numbers in this assay, from the lowest: compound 2; then compound 3; then compounds 4 and 1 (each within the scatter of the next).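

In this assay, the full replacement of 4-cyanophenyl by 5-(methylcarbamoyl)pyrazin-2-yl on the oxygen gives a large step, a 14-fold higher number from compound 2 to compound 4 (1.14 log units; beyond the scatter), so a group with a donor on the amide still reaches the top of the series. Hydrogen in place of methyl on the amide-type nitrogen gives a 1.1-fold lower number from compound 1 to compound 4 (0.03 log units; within the scatter), so the amide hydrogen costs nothing measurable on this read-out. Open, going by these compounds, is whether a carboxylic acid or an amine in place of methylcarbamoyl would hold this number. Nothing on hand explains these numbers.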